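A shorter chain on the shared core

The source may hold more compounds than are shown below. What is called first, only, known or untested is meant among the compounds shown, and "the series" means these compounds.

In a functional assay on MDA-MB-231 cells (Homo sapiens) for inhibition, read by MTT assay, with stated times of 18 h and 4 h (a higher number here means a weaker inhibitor, a lower number a stronger inhibitor), three compounds that differ only in the length of one chain have been measured. Compound 1 `CCCCCCCCCCOP(=O)(O)OCCSC(=S)N1CCCCCC1` gives 11400 nM, compound 2 `CCCCCCCCOP(=O)(O)OCCSC(=S)N1CCCCCC1` gives 27000 nM and compound 3 `CCCCCCOP(=O)(O)OCCSC(=S)N1CCCCCC1` gives 17200 nM. Compound 3 thus stands within the scatter of each of the other two.

Compound 4 `CCCOP(=O)(O)OCCSC(=S)N1CCCCCC1` shortens the chain again, from hexyl to propyl: hydrogen in place of propyl on a saturated chain carbon, three bonds along the chain from an oxygen on an unsaturated carbon. The change lies on a saturated chain carbon, three bonds along the chain from an oxygen on an unsaturated carbon.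

All three measured steps are shortenings of this same chain, and none is large. The only one beyond the scatter, a 2.4-fold higher number from compound 1 to compound 2 (0.37 log units; beyond the scatter), points to a higher number on shortening. Against that trend stand a 1.6-fold lower number from compound 2 to compound 3 (0.20 log units; within the scatter) and a 1.5-fold higher number from compound 1 to compound 3 (0.18 log units; within the scatter), both within the scatter. No chain as short as propyl has been measured, so the direction remains uncertain.

A slight rise is expected, and the expected change is small: a 1.6-fold higher number from compound 3 to compound 4 (0.21 log units; within the scatter). Compound 4 is estimated at 28000 nM, with an expected range of 13000 nM to 60000 nM.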

Compound 4, half-maximal inhibitory concentration: 38000 nM
Compound 4: middle estimate off by 1.4-fold (0.13 log units), on the low side; the range from low to high includes it.
By their numbers in this assay, from the lowest: compounds 1, 3, 2 and 4 (each within the scatter of the next, the first and the last beyond it).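

Among these compounds, with the chain cut to propyl, shortening gives a step beyond the scatter from the hexyl compound for the first time, a 2.2-fold higher number from compound 3 to compound 4 (0.34 log units; beyond the scatter), and in this assay the two ends of the series now lie furthest apart, with a 3.3-fold higher number from compound 1 to compound 4 (0.52 log units; beyond the scatter). Among the compounds shown here, this widens the one earlier step beyond the scatter into a broader rise from the longest chain to the shortest, although the rise is still modest. It is not a steady climb, however: compound 2 goes against it, with a 1.6-fold lower number from compound 2 to compound 3 (0.20 log units; within the scatter) and a 1.4-fold higher number from compound 2 to compound 4 (0.15 log units; within the scatter), both within the scatter, so that compound 2 cannot be told apart from either of the two shorter-chain compounds.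

Nothing on hand accounts for these steps, and they say only how the number moves with chain length. On these data alone, it remains open whether an ethyl or methyl chain at this place would carry the rise further, and whether a chain ending in an amine or a carboxylic acid would follow the same course.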